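A few compounds are considered here, and "the series" means these few. Any claim that something is new, unique, unknown or untested is made for them only; others in the source may bear on it.

Compound 1 `O=C(c1c(O)ccc2cc(-c3cccc(O)c3)ccc12)N1CCOCC1` was tested in an in vitro assay on Sf9 cells for inhibition of 17-beta-hydroxysteroid dehydrogenase type 1 (Homo sapiens), tested at 1 uM (a higher number here means a stronger effect of the compound at the concentration tested, a lower number a weaker effect), and gives 62%. Among the three compounds measured so far it stands second highest: compound 2 `CNC(=O)/C=C/c1c(O)ccc2cc(-c3cccc(O)c3)ccc12` gives 58% in this assay, and compound 3 `CNC(=O)CCc1c(O)ccc2cc(-c3cccc(O)c3)ccc12` gives 80%. The step of a number 4 percentage points lower from compound 1 to compound 2 (within the scatter) is within the scatter, so compounds 1 and 2 cannot be told apart on these numbers, while the step of a number 18 percentage points higher from compound 1 to compound 3 (beyond the scatter) and the step of a number 22 percentage points higher from compound 2 to compound 3 (beyond the scatter) are both beyond it.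

Compound 4 `O=C(Nc1cccc(O)c1)c1c(O)ccc2cc(-c3cccc(O)c3)ccc12` has not yet been measured in this assay. Its change from compound 1 is (3-hydroxyphenyl)amino in place of morpholin-4-yl on a carbonyl carbon. Within the data shown here, none of the measured steps touches this place in the same way: the steps from compound 1 to compound 2 and from compound 1 to compound 3 replace the whole group on the aromatic carbon, carbonyl included, whereas here the carbonyl stays and only the group attached to it is exchanged. The measured steps therefore bear on this change only loosely; they show that swaps at this part of the shared core move the read-out by modest amounts at most, in either direction. On that basis a step of a number 3 percentage points higher from compound 1 to compound 4 (within the scatter) is expected, and compound 4 is estimated to give 65% in this assay, with a range from 40% to 85%.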

Compound 4, a percentage reported as inhibition, at one concentration (the size of the read-out at that concentration, not a potency): 70%
Estimate against measurement, compound 4: 5 percentage points below, and the stated range covers the measured number.
By their numbers in this assay, from the lowest: compounds 2, 1, 4 and 3 (each within the scatter of the next, the first and the last beyond it).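

Among these compounds, exchanging morpholin-4-yl for (3-hydroxyphenyl)amino on the carbonyl carbon gives a step of a number 8 percentage points higher from compound 1 to compound 4 (within the scatter) in this assay, and this is the first pair here in which the carbonyl stays and only the group attached to it is exchanged. The two groups differ considerably on paper: a non-aromatic ring with 0 hydrogen-bond donors and 6 heavy atoms leaves, and an aromatic ring of carbon only enters, in a group with 2 hydrogen-bond donors and 8 heavy atoms, yet the read-out at the single concentration tested does not tell the two compounds apart, so this position accepts this particular exchange. No available measurement explains why so large a structural exchange leaves the read-out within the scatter.

Still open, as far as these compounds go, is which part of the (3-hydroxyphenyl)amino group matters, a question that a plain phenylamino group without the hydroxyl, or a small methylamino group on the same carbonyl carbon, could help to answer. Also open, from the compounds shown here alone, is how (3-hydroxyphenyl)amino would behave in place of the methylamino group at the end of the saturated chain in compound 3.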